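This account rests on a few compounds, and the source may have more. Where it says the series, first, only, none or still open, it means among the compounds named here.

Series notes. In a functional assay on HCT-116 cells (Homo sapiens) for antiproliferative activity, read by sulforhodamine B assay, with a stated time of 72 h (a lower number here means a stronger inhibitor, a higher number a weaker inhibitor), compound 1 `COc1ncc(-c2ccc3ncnc(Nc4ccc(OCCCO)nc4)c3c2)cc1NS(=O)(=O)c1ccc(F)cc1F` gives 3680 nM, the second highest of the three numbers in hand. Compound 3 `COc1ncc(-c2ccc3ncnc(Nc4ccc(OCCO)nc4)c3c2)cc1NS(C)(=O)=O` gives 5360 nM, which lies within the scatter of compound 1. Compound 2 `COc1ncc(-c2ccc3ncnc(Nc4cnn(CCC(=O)O)c4)c3c2)cc1NS(C)(=O)=O` gives 1290 nM, a lower number than compound 1 and beyond the scatter; these two compounds differ in more than one place, so only their two values can be set side by side. Compound 4 `COc1cc(Nc2ncnc3ccc(-c4cnc(OC)c(NS(=O)(=O)c5ccc(F)cc5F)c4)cc23)ccc1OCCO` is not yet measured. It differs from compound 1 by 4-(2-hydroxyethoxy)-3-methoxyphenyl in place of 6-(3-hydroxypropoxy)pyridin-3-yl on a nitrogen on an aromatic ring. Within the data shown here, the one measured step at the same place is a 4.2-fold higher number from compound 2 to compound 3 (0.62 log units; beyond the scatter), which shows that exchanging the group on this nitrogen can move this assay by a modest amount. That step swaps a different pair of groups, so it indicates the likely size but not the direction. The expectation is therefore a modest step or none beyond the scatter, a 1.2-fold lower number from compound 1 to compound 4 (0.09 log units; within the scatter). Compound 4 is expected to give 3000 nM in this assay, with a range from 900 nM to 10000 nM.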

Compound 4, half-maximal inhibitory concentration: 5720 nM
Estimate against measurement, compound 4: 1.9-fold (0.28 log units) below; measured number inside the range.
By their numbers in this assay, from the lowest: compound 2; then compounds 1, 3 and 4 (each within the scatter of the next).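

In this assay, replacing 6-(3-hydroxypropoxy)pyridin-3-yl with 4-(2-hydroxyethoxy)-3-methoxyphenyl on a nitrogen on an aromatic ring gives a 1.6-fold higher number from compound 1 to compound 4 (0.19 log units; within the scatter), so the two compounds cannot be told apart here. Where a 4.2-fold higher number from compound 2 to compound 3 (0.62 log units; beyond the scatter) showed that this place can respond beyond the scatter, the new step shows that a ring of carbon only can take the place of the ring with a hetero atom without such a response, at least on the core of compound 1. No supporting measurement is available to explain this result.

As far as these compounds go, the ring, the added methoxy and the change from hydroxypropoxy to hydroxyethoxy all arrive in a single step, so their separate contributions remain open. Also open, from the compounds shown here alone, is how an amine in place of the hydroxyl at the chain end would read in this assay.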